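The source may hold more compounds than are shown below. What is called first, only, known or untested is meant among the compounds shown, and "the series" means these compounds.

Measured so far in a functional assay on HepG2 cells (Homo sapiens) for cytotoxicity, read by MTT assay, with a stated time of 72 h; a higher number here means a weaker inhibitor, a lower number a stronger inhibitor:
compound 1, `O=C(Nc1ccc(Oc2ccnc3[nH]ccc23)c(F)c1)c1nn(-c2ccc(Cl)c(F)c2)ccc1=O`, gives 9610 nM.
compound 2, `O=C(Nc1ccc(Oc2ccnc3[nH]ccc23)c(F)c1)c1nn(-c2ccc(Cl)c(C(F)(F)F)c2)ccc1=O`, gives 11900 nM.
compound 3, `Cn1ccc2c(Oc3ccc(NC(=O)c4nn(-c5ccc(Cl)c(F)c5)ccc4=O)cc3)ccnc21`, gives > 60000 nM, which is a limit of the assay and not a number.

Compound 1 and compound 2 share one core, compound 3 and compound 4 another; how the two cores differ is not broken down here. For compound 3 only a limit is known, and (the limit of > 60000 nM in this assay, at which 1 of the 3 values shown sits). Compound 1 and compound 2 are joined by one change, (trifluoromethyl in place of fluoro on an aromatic carbon), and in this assay it made a 1.2-fold higher number from compound 1 to compound 2 (0.09 log units; within the scatter). Compound 4, `Cn1ccc2c(Oc3ccc(NC(=O)c4nn(-c5ccc(Cl)c(C(F)(F)F)c5)ccc4=O)cc3)ccnc21`, is not yet measured; it arises from compound 3 by trifluoromethyl in place of fluoro on an aromatic carbon, with the same surroundings, so this is the same change. Because a 1.2-fold higher number from compound 1 to compound 2 (0.09 log units; within the scatter) left the number essentially where it was, the step from compound 3 to compound 4 is expected to be small as well. As compound 3 is known only as a limit, compound 4 is expected most likely to return a limit too. The expected step is a step that the limit leaves unreadable from compound 3 to compound 4. For compound 4 the estimate in this assay is 80000 nM, between 45000 nM and 200000 nM.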

Compound 4, half-maximal inhibitory concentration: 23400 nM
Beside the measured number, compound 4's estimate is 3.4-fold (0.53 log units) above it; measured number outside the range, below it.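

In this assay, trifluoromethyl in place of fluoro on the core of compound 3 gave an at least 2.5-fold lower number from compound 3 to compound 4 (0.40 log units; beyond the scatter), so the same change does not carry over from one core to the other with the same result: the same change on two cores in this assay, a 1.2-fold higher number (0.09 log units; within the scatter) from compound 1 to compound 2 and an at least 2.5-fold lower number (0.40 log units; beyond the scatter) from compound 3 to compound 4, at least 3.1-fold (0.50 log units) apart, beyond the scatter of two such steps The step from compound 3 starts at a limit of the assay and not a number, so only its smallest possible size is known: the limit of > 60000 nM in this assay, at which 1 of the 4 values shown sits. These two pairs show that the result of this change depended on the core here, but they do not show why, and they give no rule for any other core in the series.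

The compounds shown leave open how other groups in this place, such as a nitrile or a methoxy group, would behave on either core. They also leave open whether an amine in place of the chloro group would show the same split between the two cores.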